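Trading pyridin-3-yl for thiophen-2-yl: what to expect

The compounds below may be only part of what the source reports. "The series", "measured", "known", "first", "only" and "open" are said of these compounds alone.

In an ADME assay on LLC-MK2 cells (Macaca mulatta) for cytotoxicity, read by spectrophotometry and crystal violet staining, with a stated time of 4 days (on this read-out lower numbers stand for higher toxicity in this test and higher numbers for lower toxicity in this test), compound 3 (`CC(C)n1ncc2c(C(=O)Nc3ccccc3F)cc(-c3cccnc3)nc21`) gives 50000 nM. Compound 1 (`CC(C)n1ncc2c(C(=O)Nc3cccc(C(N)=O)c3)cc(-c3cccs3)nc21`) gives 25000 nM, and the gap between these two values lies within the usual scatter, so they cannot be told apart. Compound 2 (`CC(C)n1ncc2c(C(=O)Nc3c(F)cccc3F)cc(-c3cccs3)nc21`) gives > 200000 nM, which is a limit of this assay and not a number.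

The next compound, compound 4 (`CC(C)n1ncc2c(C(=O)Nc3ccccc3F)cc(-c3cccs3)nc21`), keeps the amide side of compound 3 but carries thiophen-2-yl in place of pyridin-3-yl on an aromatic carbon, next to the ring nitrogen: thiophen-2-yl in place of pyridin-3-yl on an aromatic carbon. Among the measured compounds shown here, no measured step makes this exact swap. For the measured compounds named here, the one measured step, an at least 8.0-fold higher number from compound 1 to compound 2 (0.90 log units; beyond the scatter), lies beyond the scatter, but it puts 2,6-difluorophenyl in place of 3-carbamoylphenyl on an amide-type nitrogen and leaves thiophen-2-yl untouched. It therefore bears on the swap only indirectly, showing that compounds with thiophen-2-yl can differ widely in this assay and that one of them reaches the limit.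

With so little to go on, a modest rise is expected, pointing towards lower toxicity, and it may not clear the scatter. The expected change is a 2.0-fold higher number from compound 3 to compound 4 (0.30 log units; within the scatter). For compound 4 the estimated value is 100000 nM, with an expected range from 35000 nM to 200000 nM.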

Compound 4, half-maximal cytotoxic concentration: 50000 nM
Beside the measured number, compound 4's estimate is 2.0-fold (0.30 log units) above it; the measured number falls inside the stated range.
By their numbers in this assay, from the lowest: compounds 1, 3 and 4 (each within the scatter of the next). At a limit, above all of these: compound 2.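

In this assay, exchanging the ring on the aromatic carbon next to the ring nitrogen gives no change at the digits printed from compound 3 to compound 4 (within the scatter), so with the 2-fluorophenyl amide held fixed, pyridin-3-yl and thiophen-2-yl cannot be told apart at this position. With thiophen-2-yl held fixed, the amide side gives two different results: 2-fluorophenyl and 3-carbamoylphenyl cannot be told apart, with a 2.0-fold higher number from compound 1 to compound 4 (0.30 log units; within the scatter), whereas putting hydrogen in place of fluoro on the 2,6-difluorophenyl ring gives an at least 4.0-fold lower number from compound 2 to compound 4 (0.60 log units; beyond the scatter). That second step can only be stated as a bound, since the value of compound 2 is a limit and not a number: the limit of > 200000 nM in this assay, at which 1 of the 4 values shown sits.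

Going by these compounds, this single pair tests the exchange only with the 2-fluorophenyl amide, so it remains open whether pyridin-3-yl and thiophen-2-yl would also match with 2,6-difluorophenyl or 3-carbamoylphenyl on the amide nitrogen. On these data alone, it also remains open how a plain phenyl ring or an amine such as morpholin-4-yl would read at this same position.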